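The compounds below may be only part of what the source reports. "The series", "measured", "known", "first", "only" and "open" are said of these compounds alone.

Measured in a physicochemical assay for solubility, in phosphate buffer, with a stated time of 18 h, at pH 7.4; on this read-out higher numbers stand for higher solubility and lower numbers for lower solubility:
- compound 1 `COc1cc2ncnc(-n3nc(-c4ccccn4)nc3N)c2cc1[N+](=O)[O-]`: 2000 nM
- compound 2 `COc1cc2ncnc(-n3nc(-c4ccccn4)nc3N)c2cc1OCCCN1CC(C)OC(C)C1`: 8000 nM
- compound 3 `COc1cc2ncnc(-n3nc(-c4ccccn4)nc3N)c2cc1OCCCNC(=O)CN1C[C@@H](C)O[C@@H](C)C1`: 34000 nM

Compound 2, at 8000 nM, stands in the middle of these three numbers, with compound 1 lower and compound 3 higher. The next compound to be considered is compound 4 `COc1cc2ncnc(-n3nc(-c4ccccn4)nc3N)c2cc1OCCNC(=O)OC(C)(C)C`. Its difference from compound 2 is (tert-butoxycarbonyl)amino in place of (2,6-dimethylmorpholin-4-yl)methyl on a saturated chain carbon, two bonds along the chain from an oxygen on an aromatic ring. Read one bond further out, 3-(2,6-dimethylmorpholin-4-yl)propoxy gives way to 2-((tert-butoxycarbonyl)amino)ethoxy.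

Among the measured compounds shown here, no measured step makes this exact exchange. The closest is a 4.0-fold higher number from compound 1 to compound 2 (0.60 log units; beyond the scatter), where 3-(2,6-dimethylmorpholin-4-yl)propoxy stood in place of nitro. The other, a 4.3-fold higher number from compound 2 to compound 3 (0.63 log units; beyond the scatter), kept the 2,6-dimethylmorpholin-4-yl group and is a weaker guide. Since compound 4 also lacks that group, a modest step towards a lower number in this assay is expected, similar in size to the first step read in reverse. For the measured compounds named here, this remains an expectation from only two steps.

The estimated change is a 3.2-fold lower number from compound 2 to compound 4 (0.51 log units; beyond the scatter). For compound 4 the expected value is 2500 nM, with an estimated range of 700 nM to 8000 nM.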

Compound 4, solubility: 2000 nM
The estimate for compound 4 lay 1.3-fold (0.10 log units) above the measured number, and the stated range covers the measured number.
By their numbers in this assay, from the lowest: compounds 1 and 4 (each within the scatter of the next); then compound 2; then compound 3.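

In this assay, the step with (tert-butoxycarbonyl)amino in place of (2,6-dimethylmorpholin-4-yl)methyl gave a 4.0-fold lower number from compound 2 to compound 4 (0.60 log units; beyond the scatter), so the higher number seen earlier with the 3-(2,6-dimethylmorpholin-4-yl)propoxy group does not carry over to the 2-((tert-butoxycarbonyl)amino)ethoxy group. The step with 2-((tert-butoxycarbonyl)amino)ethoxy in place of nitro on an aromatic carbon gave no change at the digits printed from compound 1 to compound 4 (within the scatter), which shows that an ether chain on this carbon does not in itself separate a compound from the nitro compound. No measurement shown here accounts for either step.

As far as these compounds go, the step to compound 4 changes both the chain length and the end group, so the share of each stays open. From the compounds shown here alone, whether a 3-((tert-butoxycarbonyl)amino)propoxy group or an ethoxy chain ending in a free amine would behave like compound 4 or like compound 2 also remains unknown.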